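This account rests on a few compounds, and the source may have more. Where it says the series, first, only, none or still open, it means among the compounds named here.

Measured so far in a functional assay, read by spectrophotometry, with a stated time of 2 h; on this read-out higher numbers stand for weaker inhibition and lower numbers for stronger inhibition:

Compound 1, `CCOC(=O)N1CCC(=NNC(=O)c2ccc(C(F)(F)F)cc2)CC1`: 33800 nM
Compound 2, `CCOC(=O)N1CCC(=NNC(=O)c2ccc([N+](=O)[O-])cc2)CC1`: 51700 nM
Compound 3, `O=C(NN=C1CC(c2ccccc2)NC(c2ccccc2)C1)c1ccc(C(F)(F)F)cc1`: 65000 nM

Compound 1 and compound 2 share a core and differ by nitro in place of trifluoromethyl on an aromatic carbon; this assay gives a 1.5-fold higher number from compound 1 to compound 2 (0.18 log units; within the scatter). Compound 3 carries a different core, and the difference between the two cores is not broken down here. Compound 4, `O=C(NN=C1CC(c2ccccc2)NC(c2ccccc2)C1)c1ccc([N+](=O)[O-])cc1`, is not yet measured; it differs from compound 3 by nitro in place of trifluoromethyl on an aromatic carbon, the same kind of change seen from compound 1 to compound 2. Compound 3 stands within the scatter of both compound 1 and compound 2. Among the measured compounds shown here, on the one earlier step, compound 4 is expected to show a 1.5-fold higher number from compound 3 to compound 4 (0.16 log units; within the scatter) in this assay. The estimate for compound 4 is therefore 95000 nM, expected between 40000 nM and 250000 nM.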

Compound 4, half-maximal inhibitory concentration: 88100 nM
Compound 4: middle estimate off by 1.1-fold (0.03 log units), on the high side, and the stated range covers the measured number.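

In this assay, putting nitro in place of trifluoromethyl gives a 1.4-fold higher number from compound 3 to compound 4 (0.13 log units; within the scatter), and the step matches the one on the other core: the same change on two cores in this assay, a 1.5-fold higher number (0.18 log units; within the scatter) from compound 1 to compound 2 and a 1.4-fold higher number (0.13 log units; within the scatter) from compound 3 to compound 4, 1.1-fold (0.05 log units) apart, within the scatter of two such steps. Within these two pairs, then, the change carries from one core to the other with no detectable difference in size. Both steps lie within the scatter, however, so this is agreement between two small steps; it does not show a real effect of the change on either core, and two cores make no rule for the series.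

The compounds shown leave open whether another group at this place, such as an amine, a nitrile or a carboxylic acid, would shift the number beyond the scatter. They also leave open whether the same step would hold on any further core.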